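This account rests on a few compounds, and the source may have more. Where it says the series, first, only, none or still open, it means among the compounds named here.

Notes on the series.

Compound 1 `Cc1ccc(/C=C2\CCC/C(=C\c3ccccc3[N+](=O)[O-])C2=O)cc1` gives in a physicochemical assay for lipophilicity (a lower number here means a more polar compound, a higher number a more lipophilic compound), a reading of 5.15. Compound 2 `COc1ccc(/C=C2\CCC/C(=C\c3ccccc3[N+](=O)[O-])C2=O)cc1` differs from compound 1 by methoxy in place of methyl on an aromatic carbon; in this assay compound 2 gives 4.76, so the change made a number 0.39 log units lower from compound 1 to compound 2 (beyond the scatter). Compound 3 `Cc1ccc(/C=C2\CCC/C(=C\c3ccc([N+](=O)[O-])cc3)C2=O)cc1` holds the same atoms as compound 1 joined differently; the difference between the two cores is not broken down here. In this assay compound 3 gives 5.38. Set against compound 1, the gap between the two numbers lies within the scatter of the measurement; set against compound 2, it lies beyond it.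

Compound 4 `COc1ccc(/C=C2\CCC/C(=C\c3ccc([N+](=O)[O-])cc3)C2=O)cc1` has not been measured. From compound 3 it differs by methoxy in place of methyl on an aromatic carbon, the same change as that from compound 1 to compound 2, occurring twice among these four compounds and with the place described in the same words both times. Among the compounds with values here, the step expected in this assay is a number 0.38 log units lower from compound 3 to compound 4 (beyond the scatter), set beside the one measured step of this change, a number 0.39 log units lower from compound 1 to compound 2 (beyond the scatter), which is the only measured instance and the sole ground for the expectation. With the core difference between compound 1 and compound 3 not broken down, nothing further checks whether the change carries over unaltered. Compound 4 is estimated to give 5, with a range from 4.7 to 5.3.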

Compound 4, partition coefficient: 4.98
The estimate for compound 4 lay 0.02 log units above the measured number, and the stated range covers the measured number.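

In this assay, within the data shown here, the change from 4-methylphenyl to 4-methoxyphenyl now gives a number 0.40 log units lower from compound 3 to compound 4 (beyond the scatter), set beside a number 0.39 log units lower from compound 1 to compound 2 (beyond the scatter), so both measured instances run in the same direction and lie beyond the scatter, and no compound among the four goes against this. This shows that the step carried over closely between these two cores, which hold the same atoms joined differently, but two pairs cannot show that it would do so on any other core, and the match does not break down the difference between the cores themselves. Nothing measured alongside these readings bears on what lies behind the step.

From the compounds shown here alone, the four compounds carry only methyl or methoxy at this place on the aromatic ring, so it remains open whether an ethoxy group or a longer chain, an amine or a carboxylic acid there would give a reading that follows the same course on both cores. Going by these compounds, it also remains open whether the step keeps its size when the rest of the shared core is changed in any way other than the one seen between these two cores.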